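Aryl swap on the hexyl acid series: compound 3 to 4

The compounds below may be only part of what the source reports. "The series", "measured", "known", "first", "only" and "open" are said of these compounds alone.

Working notes on a short series of thiazolylamino pyrimidine acids tested in an assay for inhibition of Polyunsaturated fatty acid 5-lipoxygenase (Homo sapiens), read by HPLC, with stated times of 15 min and 10 min; on this read-out higher numbers stand for weaker inhibition and lower numbers for stronger inhibition. Compound 1 `CCC(Sc1nc(Cl)cc(Nc2nc(-c3ccc(Cl)cc3)cs2)n1)C(=O)O` gives 3600 nM. Compound 2 `O=C(O)CSc1nc(Cl)cc(Nc2nc(-c3ccc(Cl)cc3)cs2)n1`, which carries hydrogen in place of ethyl on the chain carbon bound to the carbonyl carbon and the sulfur, reaches only the limit of this assay, > 10000 nM. The step of an at least 2.7-fold higher number from compound 1 to compound 2 (0.44 log units; beyond the scatter) shows that shortening the chain weakens inhibition, with the value of compound 2 sitting at the limit of > 10000 nM in this assay, at which 1 of the 3 values shown sits. Compound 3 `CCCCCCC(Sc1nc(Cl)cc(Nc2nc(-c3cccc4ccccc34)cs2)n1)C(=O)O`, with a hexyl chain on that carbon and naphthalen-1-yl on the thiazole ring, gives 400 nM and stands lowest of the two numbers shown, with compound 1 nearest at a clearly higher number.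

Compound 4 `CCCCCCC(Sc1nc(Cl)cc(Nc2nc(-c3ccc(Cl)cc3Cl)cs2)n1)C(=O)O` is not yet measured. It differs from compound 3 only in 2,4-dichlorophenyl in place of naphthalen-1-yl on an aromatic carbon. Among the compounds with values here, no measured step touches the aryl group on the five-membered ring; the single measured step concerns the chain and does not bear on this change. The hexyl chain of compound 3 is kept, so compound 4 is expected to stay closer to compound 3 than to compound 1. For compound 4 a number of about 800 nM is estimated, within 250 nM to 3000 nM, the expected step being a 2.0-fold higher number from compound 3 to compound 4 (0.30 log units; within the scatter).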

Compound 4, half-maximal inhibitory concentration: 800 nM
For compound 4 middle estimate and measured number coincide at the digits printed, within the range that was stated.
By their numbers in this assay, from the lowest: compounds 3 and 4 (each within the scatter of the next); then compound 1. At a limit, above all of these: compound 2.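

Notes on the aryl position: with the hexyl chain held fixed, the aromatic carbon of the five-membered aromatic ring with 1 nitrogen and 1 sulfur, next to the ring nitrogen, now has its first measured step in this assay, and the earlier step concerned the chain alone: a 2.0-fold higher number from compound 3 to compound 4 (0.30 log units; within the scatter). This step stays within the scatter, so 2,4-dichlorophenyl, with one six-membered aromatic ring and two chlorines, cannot be told apart from naphthalen-1-yl, with two six-membered aromatic rings, on this read-out. Nothing measured in this short series gives a reason for this result.

The compounds shown leave open how much of the gap between the hexyl compounds and compound 1 belongs to the chain and how much to the aryl group, since no pair shown separates hexyl from ethyl on a single aryl group. Also open, on these data alone, is how this position would respond to a phenyl ring carrying an amine, and how a chain longer than hexyl on the carbon bound to the carbonyl carbon and the sulfur would read.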